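Chlorine Added at the Outer Ring: What to Expect

A few compounds are considered here, and "the series" means these few. Any claim that something is new, unique, unknown or untested is made for them only; others in the source may bear on it.

Of the compounds shown here, three have been measured in a physicochemical assay for lipophilicity, in phosphate buffer, measured as octanol-water partition, with a stated time of 24 h; a lower number here means a more polar compound, a higher number a more lipophilic compound. Compound 1 `S=C(N/N=C/c1ccc(Oc2ccc3ccccc3c2)cc1)Nc1ccc(Cl)cc1` gives 6.96, compound 2 `S=C(N/N=C/c1ccc(Oc2ccccc2)cc1)Nc1ccc(Cl)cc1` gives 5.64, and compound 3 `Fc1ccc(Oc2ccc(/C=N/NC(=S)Nc3ccccc3)cc2)cc1` gives 5.09. For the measured compounds named here, the one step between compounds that differ in a single place is a number 1.32 log units lower from compound 1 to compound 2 (beyond the scatter). Compound 3 stands lowest of the three, with compound 2 nearest above it and compound 1 farthest, both gaps beyond the scatter.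

Compound 4 `Fc1ccc(Oc2ccc(/C=N/NC(=S)Nc3ccc(Cl)cc3)cc2)cc1` is not yet measured. It differs from compound 3 by chloro in place of hydrogen on an aromatic carbon. Going by the values given here, no measured step concerns this particular change; the single known step, from compound 1 to compound 2, swaps a naphthalen-2-yl for a phenyl and is of a different kind, so it gives only a sense of scale, not a direct guide. For compound 4 the expected step is a number 0.71 log units higher from compound 3 to compound 4 (beyond the scatter), upward and beyond the scatter. Compound 4 is therefore estimated at 5.8, within a range from 5.4 to 6.3.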

Compound 4, partition coefficient: 5.84
Estimate against measurement, compound 4: 0.04 log units below, within the range that was stated.
By their numbers in this assay, from the lowest: compound 3; then compounds 2 and 4 (each within the scatter of the next); then compound 1.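

In this assay, for the compounds shown here, chloro in place of hydrogen on an aromatic carbon, para to a large group, gives the first measured step for this change (a number 0.75 log units higher from compound 3 to compound 4 (beyond the scatter)), and it is modest. Adding one fluoro does not separate the compounds it links (a number 0.20 log units higher from compound 2 to compound 4 (within the scatter)), so that change shows no clear shift in this assay. With 4-fluorophenyl in place of naphthalen-2-yl on an oxygen on an aromatic ring, the step is large (a number 1.12 log units lower from compound 1 to compound 4 (beyond the scatter)), so swapping that whole group counts for more here than adding one chloro.

No measurement shown explains why any of these steps has its size. On these data alone, it also remains open how an amine or a carboxylic acid in place of chloro at this position would compare, and whether chloro gives a similar step on other cores.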